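Isopropyl in Place of Methyl: Expecting Compound 3

The source may hold more compounds than are shown below. What is called first, only, known or untested is meant among the compounds shown, and "the series" means these compounds.

Compound 1 `COc1ccc(-n2cnc3cnc(-c4ccc(F)cc4C)cc32)cc1OC`: 15 nM
Compound 2 `COc1ccc(-n2cnc3cnc(-c4ccc(F)cc4C)cc32)cc1C`: 14 nM

In a functional assay on HL-60 cells (Homo sapiens) for activation, read by flow cytometry, with a stated time of 4 days (on this read-out lower numbers stand for an effect already at smaller amounts and higher numbers for an effect only at larger amounts of compound), compound 2 shows the smaller of the two numbers, yet the step of a 1.1-fold lower number from compound 1 to compound 2 (0.03 log units; within the scatter) lies within the scatter, so the two compounds cannot be told apart. Compound 3 `COc1ccc(-n2cnc3cnc(-c4ccc(F)cc4C)cc32)cc1C(C)C` carries isopropyl in place of methyl on an aromatic carbon. Within the data shown here, the only step that bears on this place, from methoxy to methyl, changed little, so a larger group at the same place is expected to move the number only modestly, if at all, in this assay. The step of a 1.4-fold higher number from compound 2 to compound 3 (0.15 log units; within the scatter) is my estimate; compound 3 is expected to give 20 nM, within 6 nM to 70 nM.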

Compound 3, half-maximal effective concentration: > 10000 nM
Compound 3 was reported as a limit (the forecaster's own chance of this, stated with the estimate: 3%); at least 500-fold (2.69 log units) between middle value and limit.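

Methoxy and methyl gave values that cannot be told apart, but this place does not accept every small group. In this assay the change to isopropyl gives an at least 710-fold higher number from compound 2 to compound 3 (2.85 log units; beyond the scatter), and the comparison with methoxy gives an at least 660-fold higher number from compound 1 to compound 3 (2.82 log units; beyond the scatter). Compound 3 stands at a limit of the assay, not at a number: the limit of > 10000 nM in this assay, at which 1 of the 3 values shown sits.

The compounds shown leave open whether an ethyl group, with a size between methyl and isopropyl, would keep the effect. They also leave open whether an amine at this place would do so.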